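The source may report more compounds than this note shows. Statements on the series, on what has been measured and on what is new or still open speak of the compounds shown alone.

Measured in a physicochemical assay for solubility, in phosphate buffer, at pH 7.4; a higher number here means a more soluble compound, a lower number a less soluble compound:
- compound 1 `OCCC1CCN(c2nccnc2OC2CN(c3ccc4ccccc4n3)C2)CC1`: 84000 nM
- compound 2 `c1ccc(-c2nccnc2OC2CN(c3ccc4ccccc4n3)C2)cc1`: < 1000 nM (a limit of the assay, not a number)

In this assay, compound 2 has no exact value, only the limit < 1000 nM. Among the compounds with values here, its true position is therefore not known, and only one of the two compounds has a measured number. The next compound, compound 3 `c1ccc2ncc(-c3nccnc3OC3CN(c4ccc5ccccc5n4)C3)cc2c1`, has quinolin-3-yl in place of phenyl on an aromatic carbon.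

Within the data shown here, one measured step bears on this change, and only indirectly. It is the large drop an at least 84-fold lower number from compound 1 to compound 2 (1.92 log units; beyond the scatter), beyond the scatter, and it ends at the limit noted here: the limit of < 1000 nM in this assay, at which 1 of the 2 values shown sits. That step put phenyl on the same aromatic carbon, replacing 4-(2-hydroxyethyl)piperidin-1-yl, whereas the new change swaps one aromatic group for another. Among the measured compounds shown here, no measured pair shows a swap of that kind. The expectation is therefore no step beyond the scatter in either direction, and the result may again be only a limit. The expected change is a step that the limit leaves unreadable from compound 2 to compound 3. In this assay, compound 3 is estimated at 600 nM, with an expected range from 200 nM to 1500 nM.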

Compound 3, solubility: < 1000 nM
Compound 3 ended at the assay's limit (the forecaster's own chance of this, stated with the estimate: 80%); the middle value does not contradict the limit.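

In this assay, compound 3 gives < 1000 nM, which is a limit of the assay and not a number. Placing quinolin-3-yl on this aromatic carbon in place of 4-(2-hydroxyethyl)piperidin-1-yl gives an at least 84-fold lower number from compound 1 to compound 3 (1.92 log units; beyond the scatter), so a second aromatic group, this one with a ring nitrogen and a hydrogen-bond acceptor, also ends at the limit and not at a measured number. The swap of phenyl for quinolin-3-yl itself cannot be read, and the two compounds cannot be placed relative to each other, as both rest on the same limit: the limit of < 1000 nM in this assay, at which 2 of the 3 values shown sit.

As far as these compounds go, how far compound 2 and compound 3 lie past that limit stays open, and so does whether the ring nitrogen of quinolin-3-yl makes any difference to the read-out. Also open, from the compounds shown here alone, is what a different group on this aromatic carbon would give, such as a carboxylic acid, a simple amine, or a piperidine without the hydroxyethyl chain, and whether the value of compound 1 depends on that chain or on the saturated ring.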